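Swapping the aroyl group of compound 3 for a hydroxypiperidinylacetyl

The source may report more compounds than this note shows. Statements on the series, on what has been measured and on what is new or still open speak of the compounds shown alone.

For the measured compounds named here, compound 3 `O=C(c1ccccc1Cl)N1N=C(c2cc3ccccc3oc2=O)CC1c1ccccc1` is one of three compounds measured in a functional assay on HepG2 cells (Homo sapiens) for cytotoxicity, read by MTT assay, with a stated time of 48 h; a higher number here means a weaker inhibitor, a lower number a stronger inhibitor. There compound 3 gives 5440 nM, the second highest of the three numbers; compound 1 `CC1=NN(C(=O)CN2CCCCC2)C(c2ccccc2O)C1` gives 3020 nM, which lies within the scatter of compound 3, and compound 2 `CC1=NN(C(=O)CN2CCC(Cl)CC2)C(c2ccccc2O)C1` gives 42100 nM, well beyond it. Going by the values given here, the only step measured between single-change neighbours is a 14-fold higher number from compound 1 to compound 2 (1.14 log units; beyond the scatter), a large rise in the number on adding chloro to a saturated ring carbon.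

Compound 4 `O=C(CN1CCC(O)CC1)N1N=C(c2cc3ccccc3oc2=O)CC1c1ccccc1` differs from compound 3 by (4-hydroxypiperidin-1-yl)methyl in place of 2-chlorophenyl on a carbonyl carbon. Among the compounds with values here, no measured step covers this exchange of the group on the carbonyl carbon; the one measured step concerns a change elsewhere, on a saturated ring carbon, and only shows that altering the piperidine ring can move the number strongly. Compound 1 carries the unsubstituted piperidinylmethyl on its carbonyl and sits close to compound 3, so the estimate leans on that neighbourhood and allows for the hydroxy group to shift the number either way. The expected step is a 1.3-fold higher number from compound 3 to compound 4 (0.11 log units; within the scatter), which may not exceed the scatter. Compound 4 is therefore estimated at 7000 nM in this assay, with a range from 2500 nM to 25000 nM.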

Compound 4, half-maximal inhibitory concentration: "not active" (no number reported)
The entry for compound 4 holds no number; the estimate stays without a comparison.
By their numbers in this assay, from the lowest: compounds 1 and 3 (each within the scatter of the next); then compound 2.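

For the compounds shown here, compound 4 is reported in this assay as "not active" with no number, so no step from compound 3 to compound 4 can be read. Nothing measured here bears on this result. The compounds shown leave open how (4-hydroxypiperidin-1-yl)methyl compares numerically with 2-chlorophenyl on this carbonyl carbon.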